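Chloro addition to compound 2: expected permeability step

The source may hold more compounds than are shown below. What is called first, only, known or untested is meant among the compounds shown, and "the series" means these compounds.

Measured in an ADME assay for permeability, using PAMPA; on this read-out lower numbers stand for lower permeability and higher numbers for higher permeability:
- compound 1 `O=C(Nc1ccc([N+](=O)[O-])cc1Cl)c1cnc2ccccc2c1O`: 499 10^-6 cm/s
- compound 2 `O=C(Nc1ccc([N+](=O)[O-])cc1)c1cc(Cl)ccc1O`: 127 10^-6 cm/s

Among the measured compounds shown here, only these two compounds have values so far. Compound 2 holds the lower one, at 127 10^-6 cm/s, and its gap to compound 1, at 499 10^-6 cm/s, lies beyond the scatter. The two compounds differ in more than one place, so their gap gives no direct measure of any single change.

Compound 3 `O=C(Nc1ccc([N+](=O)[O-])c(Cl)c1)c1cc(Cl)ccc1O` is not yet measured and differs from compound 2 in one place: chloro in place of hydrogen on an aromatic carbon. This is chloro in place of hydrogen on an aromatic carbon, ortho to a nitro group and meta to a large group.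

For the measured compounds named here, the series holds no measured example of this change, so the expectation is loose. In this assay, no step beyond the scatter is expected, with a slight lean towards a higher number. The expected step is a 1.5-fold higher number from compound 2 to compound 3 (0.17 log units; within the scatter). The upper end of the range is left wide, as compound 1 stands at 499 10^-6 cm/s. Compound 3 is estimated at 190 10^-6 cm/s, with an expected range of 100 10^-6 cm/s to 380 10^-6 cm/s.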

Compound 3, apparent permeability: 68 10^-6 cm/s
Estimate against measurement, compound 3: 2.8-fold (0.45 log units) above, and the stated range ends above it.
By their numbers in this assay, from the lowest: compounds 3 and 2 (each within the scatter of the next); then compound 1.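

In this assay, among the compounds shown here, the step of a 1.9-fold lower number from compound 2 to compound 3 (0.27 log units; within the scatter) for chloro in place of hydrogen on an aromatic carbon is the first single-place measure the series offers, and it lies within the usual scatter of repeated measurements. For the compounds shown here, at this position, ortho to a nitro group and meta to a large group, a single added chlorine therefore produces no step that can be told from repeat variation, at least on the background shared by compound 2 and compound 3. No measurement available here bears on why the step has this size.

As far as these compounds go, with one chloro example, it remains open whether a different group at this position, such as an amine, a carboxylic acid or a longer chain, would stay within the scatter or move the number beyond it, and whether chloro would behave the same way at another aromatic carbon of this ring. Compound 1 differs from compound 2 and compound 3 in more than one place, so what sets its value apart also remains unassigned until single-place steps connect it to them.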